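The compounds below may be only part of what the source reports. "The series", "measured", "known", "first", "only" and "open" are said of these compounds alone.

Measured in a physicochemical assay for lipophilicity, read by LC-MS, using the shake flask method, with a stated time of 1 h, at pH 7.4; on this read-out higher numbers stand for higher lipophilicity and lower numbers for lower lipophilicity:
compound 1 `O=S(=O)(O)CCc1ccccc1`: -1.45
compound 2 `O=C1CC(c2ccccc2)C=C1O`: 1.71
compound 3 `CC1=C(O)CC(Cc2ccccc2)C1=O`: -0.33

Of these three, compound 1 has the lowest number. Compound 3 lies nearest to it and compound 2 furthest, and both gaps are beyond the usual scatter of repeated measurements.

The next compound to be measured is compound 4 `O=S(O)CCc1ccccc1`, which differs from compound 1 in one place: hydroxysulfinyl in place of sulfo on a saturated chain carbon, two bonds along the chain from an aromatic carbon. In words, hydroxysulfinyl stands in place of sulfo on a saturated chain carbon, two bonds along the chain from an aromatic carbon.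

Among the compounds with values here, no two measured compounds differ in only one place, so the data offer no measured step as a guide. The estimate therefore starts from compound 1 at -1.45, and a modest upward move in this assay is expected, close to the edge of the scatter. The expected step is a number 0.35 log units higher from compound 1 to compound 4 (beyond the scatter). For compound 4 the estimated value is -1.1, with an expected range from -1.7 to -0.5.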

Compound 4, distribution coefficient: -1.3
Compound 4: the middle estimate sits 0.20 log units above what was measured; the range from low to high includes it.
By their numbers in this assay, from the lowest: compounds 1 and 4 (each within the scatter of the next); then compound 3; then compound 2.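

In this assay, within the data shown here, the exchange of sulfo for hydroxysulfinyl on a saturated chain carbon, two bonds along the chain from an aromatic carbon, gives a number 0.15 log units higher from compound 1 to compound 4 (within the scatter) and so supplies the first measured single change in the set. Among these compounds, at this place, going from sulfo with 4 heavy atoms and 2 hydrogen-bond acceptors to hydroxysulfinyl with 3 heavy atoms and 1 hydrogen-bond acceptor does not separate compound 1 and compound 4 on this read-out, something the earlier compounds could not show. No measurement shown accounts for this result.

The compounds shown leave open whether a carboxylic acid or an amine on the same saturated chain carbon would also stay within the scatter of compound 1. They also leave open whether the same exchange would behave alike on a longer chain.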